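The source may hold more compounds than are shown below. What is called first, only, known or untested is meant among the compounds shown, and "the series" means these compounds.

Measured so far in a functional assay on SAOS-2 cells (Homo sapiens) for antiproliferative activity, read by MTT assay, with a stated time of 72 h; on this read-out lower numbers stand for stronger inhibition and higher numbers for weaker inhibition:
compound 1 `CCOC1=C(C(=O)c2ccccc2)C(c2ccc(Br)cc2)N(CCCn2ccnc2)C1=O` gives 31700 nM
compound 2 `O=C(C1=C(OC2CCCCC2)C(=O)N(CCCn2ccnc2)C1c1ccc(Br)cc1)c1ccccc1` gives 29700 nM
compound 3 `O=C(C1=C(Nc2ccccc2)C(=O)N(CCCn2ccnc2)C1c1ccc(Br)cc1)c1ccccc1` gives 24400 nM

Compound 3 stands apart from neither of the others: a 1.3-fold lower number from compound 1 to compound 3 (0.11 log units; within the scatter) and a 1.2-fold lower number from compound 2 to compound 3 (0.09 log units; within the scatter), and likewise a 1.1-fold lower number from compound 1 to compound 2 (0.03 log units; within the scatter). The three groups on the double-bonded ring carbon thus give indistinguishable numbers in this assay.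

Compound 4 `O=C(C1=C(Nc2ccc(Br)cc2)C(=O)N(CCCn2ccnc2)C1c1ccc(Br)cc1)c1ccccc1` differs from compound 3 by bromo in place of hydrogen on an aromatic carbon. For the measured compounds named here, none of the measured steps touches this place; all three concern the group on the double-bonded ring carbon only, and all three were within the scatter. Going by the values given here, with no step of this kind measured, the expected step is a 1.1-fold lower number from compound 3 to compound 4 (0.04 log units; within the scatter), that is, no change beyond the scatter. Compound 4 is therefore estimated at 22000 nM, between 9000 nM and 55000 nM.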

Compound 4, half-maximal inhibitory concentration: 23800 nM
The estimate for compound 4 lay 1.1-fold (0.03 log units) below the measured number; the range from low to high includes it.
By their numbers in this assay, from the lowest: compounds 4, 3, 2 and 1 (each within the scatter of the next).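

In this assay, for the compounds shown here, bromo on the aromatic ring of the anilino group gives a change further out than the earlier steps, yet the number holds (a 1.0-fold lower number from compound 3 to compound 4 (0.01 log units; within the scatter)). Measured against the oxygen-linked groups, (4-bromophenyl)amino also stays level (a 1.2-fold lower number from compound 2 to compound 4 (0.10 log units; within the scatter); a 1.3-fold lower number from compound 1 to compound 4 (0.12 log units; within the scatter)). Nothing at hand bears on why this change leaves the number in place.

The compounds shown leave open whether an amine or a carboxylic acid in place of bromo would move the number beyond the scatter. A single halogen at this place says little about other groups there.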